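Working notes: from compound 3 to compound 4

This account rests on a few compounds, and the source may have more. Where it says the series, first, only, none or still open, it means among the compounds named here.

Measured in a functional assay on MGC-803 cells (Homo sapiens) for inhibition, read by sulforhodamine B assay; a lower number here means a stronger inhibitor, a higher number a weaker inhibitor:
- compound 1 `O=C1C(Nc2ccccc2F)=CC(=O)c2c1nc1n2[C@H]2OC[C@@H](O)[C@H]2OC1`: 2000 nM
- compound 2 `O=C1C(NC2CCCC2)=CC(=O)c2c1nc1n2[C@H]2OC[C@@H](O)[C@H]2OC1`: > 16000 nM
- compound 3 `Cc1ccc(NC2=CC(=O)c3c(nc4n3[C@H]3OC[C@@H](O)[C@H]3OC4)C2=O)cc1C`: 1050 nM

The entry for compound 2 is a limit of the assay and not a number: > 16000 nM.

Compound 3 stands level with compound 1, with a 1.9-fold lower number from compound 1 to compound 3 (0.28 log units; within the scatter). Compound 3 is clearly separated from compound 2, with an at least 15-fold lower number from compound 2 to compound 3 (1.18 log units; beyond the scatter).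

The next compound, compound 4 `COc1ccc(NC2=CC(=O)c3c(nc4n3[C@H]3OC[C@@H](O)[C@H]3OC4)C2=O)cc1`, carries 4-methoxyphenyl in place of 3,4-dimethylphenyl on an amine nitrogen. The substituted phenyl type of group is kept, and only its substituents change.

Two kinds of measured step bear on this. Going by the values given here, the exchange of one substituted phenyl for another is the closest precedent, and it gave a 1.9-fold lower number from compound 1 to compound 3 (0.28 log units; within the scatter). Leaving the phenyl type altogether mattered far more, giving an at least 8.0-fold higher number from compound 1 to compound 2 (0.90 log units; beyond the scatter). Compound 4 makes no such departure, so in this assay no step beyond the scatter is expected, with at most a slight drift towards a higher number. With a single precedent, the range is kept wide.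

The expected step is a 1.2-fold higher number from compound 3 to compound 4 (0.09 log units; within the scatter).

For compound 4 the estimated value is 1300 nM, with an expected range of 500 nM to 3500 nM.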

Compound 4, half-maximal inhibitory concentration: 2150 nM
Beside the measured number, compound 4's estimate is 1.7-fold (0.22 log units) below it, and the stated range covers the measured number.
By their numbers in this assay, from the lowest: compounds 3, 1 and 4 (each within the scatter of the next, the first and the last beyond it). At a limit, above all of these: compound 2.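

In this assay, going by these compounds alone, the exchange of 3,4-dimethylphenyl for 4-methoxyphenyl on the amine nitrogen gives a 2.0-fold higher number from compound 3 to compound 4 (0.31 log units; beyond the scatter) and is the first step between two substituted phenyl groups to pass the scatter, if only modestly, so this position responds to the substituents and not only to the phenyl type. The separation does not carry over to 2-fluorophenyl, since the series shows a 1.1-fold higher number from compound 1 to compound 4 (0.03 log units; within the scatter) and leaves 4-methoxyphenyl and 2-fluorophenyl indistinguishable here. The advantage of a substituted phenyl over cyclopentyl now holds for a third phenyl group, with an at least 7.4-fold lower number from compound 2 to compound 4 (0.87 log units; beyond the scatter) read against a limit of the assay and not a number: the limit of > 16000 nM in this assay, at which 1 of the 4 values shown sits.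

Open, on these data alone, is whether the step to compound 4 belongs to the entering methoxy group or to the departing methyl groups, a question that a 4-methylphenyl group on the same amine nitrogen would address. Also open is how a benzyl group or a pyridyl ring would behave at this nitrogen, as cyclopentyl is the only group shown outside the substituted phenyl type.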